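Moving the methoxy group around the phenyl ring on the amide nitrogen

This account rests on a few compounds, and the source may have more. Where it says the series, first, only, none or still open, it means among the compounds named here.

Compound 1, `COc1ccc(N2C(=O)COc3ccc(-c4cnc(OC)c(NS(=O)(=O)c5ccc(F)cc5)c4)cc32)cc1`, gives 18400 nM in a functional assay on A-375 cells (Homo sapiens) for antiproliferative activity, read by MTT assay, with a stated time of 72 h; a higher number here means a weaker inhibitor, a lower number a stronger inhibitor.
Compound 2, `O=C1COc2ccc(-c3cnc(Cl)c(NS(=O)(=O)c4ccc(F)cc4)c3)cc2N1C1CC1`, gives 21800 nM in this assay.
Compound 3, `COc1ccc(N2C(=O)COc3ccc(-c4cnc(Cl)c(NS(=O)(=O)c5ccc(F)cc5)c4)cc32)cc1`, gives 32700 nM in this assay.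

The three measured numbers sit close together. Compound 1 has the smallest of them, but its step to compound 3 is a 1.8-fold higher number from compound 1 to compound 3 (0.25 log units; within the scatter), and compound 2 is even nearer, so none of the three can be set apart from the others. The other measured step, a 1.5-fold higher number from compound 2 to compound 3 (0.18 log units; within the scatter), is likewise within the scatter.

Compound 4, `COc1cccc(N2C(=O)COc3ccc(-c4cnc(OC)c(NS(=O)(=O)c5ccc(F)cc5)c4)cc32)c1`, differs from compound 1 only in one place: 3-methoxyphenyl in place of 4-methoxyphenyl on an amide-type nitrogen in a ring. Within the data shown here, no measured pair shows this exact change. The two steps that are known, exchanging a chloro for a methoxy group and exchanging a cyclopropyl for a 4-methoxyphenyl group, both stayed within the scatter, so there is no basis to expect the rearranged methoxyphenyl group to shift the number beyond the scatter either. The step from compound 1 to compound 4 is therefore expected to be about a 1.1-fold higher number from compound 1 to compound 4 (0.04 log units; within the scatter). Compound 4 is estimated at 20000 nM, with a range from 8000 nM to 50000 nM.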

Compound 4, half-maximal inhibitory concentration: > 40000 nM
Compound 4: only a limit was reported; the forecaster's own chance of this, stated with the estimate: 10%; at least 2.0-fold (0.30 log units) between middle value and limit.
By their numbers in this assay, from the lowest: compounds 1, 2 and 3 (each within the scatter of the next). At a limit, above all of these: compound 4.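

Among these compounds, replacing 4-methoxyphenyl with 3-methoxyphenyl on the amide-type nitrogen keeps the same atoms but joins them differently, and it gives an at least 2.1-fold higher number from compound 1 to compound 4 (0.33 log units; beyond the scatter) in this assay as the first step in this set to lie beyond the scatter. The earlier exchanges, chloro for methoxy and 4-methoxyphenyl for cyclopropyl, both stayed within the scatter, so this result shows that the place of the methoxy group on this phenyl ring can count even when the atoms stay the same. Compound 4 gives only a limit, so the step has a floor and no exact size: the limit of > 40000 nM in this assay, at which 1 of the 4 values shown sits.

Still open, on these data alone, is how an amine or a carboxylic acid in place of the methoxy group on this ring would behave. As far as these compounds go, it is also open whether the 3-methoxyphenyl group would act the same way with the chloro found in compound 3.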